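A few compounds are considered here, and "the series" means these few. Any claim that something is new, unique, unknown or untested is made for them only; others in the source may bear on it.

Three compounds share one core and differ only in a single group. Compound 1 `FC(F)(F)c1ccc(CSc2nc(Nc3ccccc3)c3ccccc3n2)cc1` carries hydrogen at that place, and in a functional assay on HGC-27 cells (Homo sapiens) for cytotoxicity, read by MTT assay, with a stated time of 72 h (a higher number here means a weaker inhibitor, a lower number a stronger inhibitor), compound 1 gives 26400 nM. Compound 2 `FC(F)(F)c1ccc(CSc2nc(Nc3ccccc3C(F)(F)F)c3ccccc3n2)cc1` carries a trifluoromethyl group there; in this assay compound 2 gives > 50000 nM, which is a limit of the assay rather than a number (the limit of > 50000 nM in this assay, at which 1 of the 3 values shown sits). Compound 3 `FC(F)(F)c1ccc(CSc2nc(Nc3cccc(Cl)c3)c3ccccc3n2)cc1` carries a chloro group, and in this assay compound 3 gives 19900 nM. Of the two plain numbers compound 3 holds the lower one, with compound 1 nearest; the gap is a 1.3-fold lower number from compound 1 to compound 3 (0.12 log units; within the scatter), so the two cannot be told apart. The change from compound 2 is an at least 2.5-fold lower number from compound 2 to compound 3 (0.40 log units; beyond the scatter), and the change an at least 1.8-fold higher number from compound 1 to compound 2 (0.27 log units; that floor lies within the scatter) is only a floor.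

Compound 4 `O=[N+]([O-])c1cccc(Nc2nc(SCc3ccc(C(F)(F)F)cc3)nc3ccccc23)c1` is built from compound 3 by one exchange: nitro in place of chloro on an aromatic carbon. Among the compounds with values here, no measured step swaps one group for another at this place; the nearest guides are a 1.3-fold lower number from compound 1 to compound 3 (0.12 log units; within the scatter), where adding chloro barely moved the number, and an at least 2.5-fold lower number from compound 2 to compound 3 (0.40 log units; beyond the scatter). The exchange is therefore expected to leave the number near that of compound 3, with no step beyond the scatter as the most likely outcome. The expected step is a 1.1-fold lower number from compound 3 to compound 4 (0.04 log units; within the scatter). Compound 4 is estimated at 18000 nM, within a range from 6000 nM to 50000 nM.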

Compound 4, half-maximal inhibitory concentration: > 50000 nM
Compound 4: only a limit was reported (the forecaster's own chance of this, stated with the estimate: 20%); middle value at least 2.7-fold (0.44 log units) from the limit.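

The earlier compounds shown here showed only that chloro at this place, on the ring carbon meta to a large group, could not be told apart from hydrogen, so the place might have seemed indifferent to what sits on it. Compound 4 shows that it is not: nitro in place of chloro gives an at least 2.5-fold higher number from compound 3 to compound 4 (0.40 log units; beyond the scatter) in this assay, a step beyond the scatter, while against hydrogen the same group gives an at least 1.8-fold higher number from compound 1 to compound 4 (0.27 log units; that floor lies within the scatter), a floor that alone would prove little. In this assay compound 4 gives > 50000 nM, which is a limit and not a number, so the full size of the loss stays hidden: the limit of > 50000 nM in this assay, at which 2 of the 4 values shown sit.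

Compound 2 and compound 4 both stand at this limit, and the step between them cannot be read. Still open is how the number would respond to other groups at this place, such as an amine, a methoxy group or a nitrile, and whether nitro on another carbon of the ring would give the same result; the compounds shown do not explain why chloro and nitro differ.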